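The compounds below may be only part of what the source reports. "The series", "measured", "known", "first", "only" and "open" are said of these compounds alone.

Compound 1 `O=C1[C@@H](NS(=O)(=O)c2ccc(-c3ccon3)s2)CCN1CCNc1ccncc1` gives 22%; compound 2 `O=C1[C@@H](NS(=O)(=O)c2ccc(-c3ccccn3)s2)CCN1Cc1cc2cc[nH]cc-2n1` gives 17%; compound 3 `O=C1[C@@H](NS(=O)(=O)c2cc3ncccc3s2)CCN1Cc1cc2c[nH]ccc-2n1` gives 61%, all in an assay on isolated protein for inhibition of coagulation factor X (Oryctolagus cuniculus), tested at 1 uM; a lower number here means less inhibition, a higher number more inhibition at the concentration tested (going by the name of the read-out).

Among these three numbers compound 1 stands second highest. Compound 2 lies a few points lower, within the usual scatter of repeated measurements, so the two cannot be told apart. Compound 3 lies far higher, beyond the scatter. Compound 4 `O=C1[C@@H](NS(=O)(=O)c2ccc(-c3ccon3)s2)CCN1Cc1cc2[nH]cccc-2n1` has not yet been measured. Compared with compound 1 it carries a group of 9 heavy atoms (7 carbon, 2 nitrogen; one five-membered aromatic ring with 1 hetero atom, one six-membered aromatic ring with 1 hetero atom) in place of a group of 8 heavy atoms (6 carbon, 2 nitrogen; one six-membered aromatic ring with 1 hetero atom), on a saturated chain carbon bound to an amide-type nitrogen in a ring. Within the data shown here, no measured pair differs in that one place, so the data give no size for such a step. The step of a number 3 percentage points higher from compound 1 to compound 4 (within the scatter) is expected to be small, not beyond the scatter. Compound 4 is therefore estimated at 25%, between 5% and 55%.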

Compound 4, a percentage reported as inhibition, at one concentration (the size of the read-out at that concentration, not a potency): 31%
Compound 4: middle estimate off by 6 percentage points, on the low side; the range from low to high includes it.
By their numbers in this assay, from the lowest: compounds 2, 1 and 4 (each within the scatter of the next, the first and the last beyond it); then compound 3.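

In this assay, among these compounds, replacing the ((pyridin-4-yl)amino)methyl group with the two-ring group, on a saturated chain carbon bound to an amide-type nitrogen in a ring, gives a number 9 percentage points higher from compound 1 to compound 4 (within the scatter) and provides the first reading of a change at this place. On the core of compound 1, this change therefore has no effect that can be told from the scatter. No available evidence bears on this result.

On these data alone, what a primary amine or a plain methyl group at this place would give remains open. So does whether the same swap would read alike on another core.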